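The source may report more compounds than this note shows. Statements on the series, on what has been measured and on what is new or still open speak of the compounds shown alone.

Measured in a functional assay on ID8 cells (Mus musculus) for antiproliferative activity; on this read-out lower numbers stand for stronger inhibition and higher numbers for weaker inhibition:
Compound 1 `O=C(Nc1ccc(O)c2c(=O)cc(-c3ccccc3Cl)oc12)c1ccccc1`: 13000 nM
Compound 2 `O=C(Nc1c(O)cc(O)c2c(=O)cc(-c3ccccc3Cl)oc12)c1ccccc1`: "not determined" (no result reported)
Compound 3 `O=c1cc(-c2ccccc2Cl)oc2c(N3CCCCC3)ccc(O)c12`: 5700 nM

Only two of these compounds carry a number. Compound 1, at 13000 nM, holds the higher of the two, so it is the weaker inhibitor of that pair. Compound 4 `C[C@@H](NC(=O)OC(C)(C)C)C(=O)Nc1ccc(O)c2c(=O)cc(-c3ccccc3Cl)oc12` is the next to be measured. It departs from compound 1 by a single change, 1-((tert-butoxycarbonyl)amino)ethyl in place of phenyl on a carbonyl carbon.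

For the measured compounds named here, only one measured step offers any guidance. This is a 2.3-fold lower number from compound 1 to compound 3 (0.36 log units; beyond the scatter), a modest change just beyond the scatter, made by putting piperidin-1-yl in place of benzamido on an aromatic carbon. That step replaces the whole benzamido, whereas compound 4 alters only the group on the carbonyl carbon, so it bears on the new change only loosely. Going by the values given here, no measured pair tests this exchange directly, and the data give no firm direction. A step of similar or smaller size is therefore expected in this assay, most likely none beyond the scatter. The estimated step is a 1.4-fold lower number from compound 1 to compound 4 (0.16 log units; within the scatter). Compound 4 is expected at 9000 nM, with an estimated range from 3000 nM to 27000 nM.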

Compound 4, half-maximal inhibitory concentration: 104000 nM
The estimate for compound 4 lay 12-fold (1.06 log units) below the measured number, and the stated range ends below it.
By their numbers in this assay, from the lowest: compound 3; then compound 1; then compound 4.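

In this assay, the group on the carbonyl carbon is not a neutral part of compound 1: putting 1-((tert-butoxycarbonyl)amino)ethyl in place of phenyl gives an 8.0-fold higher number from compound 1 to compound 4 (0.90 log units; beyond the scatter), a move towards weaker inhibition. The earlier step, a 2.3-fold lower number from compound 1 to compound 3 (0.36 log units; beyond the scatter), replaced the whole benzamido and went the other way, whereas this result shows that the number also responds when the amide-type nitrogen stays and only the group on its carbonyl carbon changes. No available evidence accounts for this shift in the number.

The exchange removes a six-membered aromatic ring and brings in a chain with no ring, a hydrogen-bond donor, two hydrogen-bond acceptors and a defined stereocentre all at once, so the compounds shown cannot say which of these features goes with the step. Going by these compounds, it remains open how a free primary amine in place of the protected amino group would read in this assay, and whether a cyclohexyl ring or a simple methyl group on the same carbonyl carbon would stay close to compound 1 or move as far as compound 4.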